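Swapping piperazine for piperidine on a weak inhibitor

The compounds below may be only part of what the source reports. "The series", "measured", "known", "first", "only" and "open" are said of these compounds alone.

Among the measured compounds shown here, compound 3 `CN1CCN(c2ccc(Nc3ncc4c(n3)N(C3CCCC3)CC(=O)N4C)nc2)CC1` gives 13100 nM in a functional assay on HeLa cells (Homo sapiens) for inhibition, read by MTT assay, with a stated time of 48 h (on this read-out lower numbers stand for stronger inhibition and higher numbers for weaker inhibition), the only number among the three measured compounds. Compound 1 `CN1CCN(c2ccc(Nc3ncc4c(n3)N(C3CCCC3)CC(=O)N4)nc2)CC1` gives only a limit of the assay, > 30000 nM. Compound 2 `CC1CCN(c2ccc(Nc3ncc4c(n3)N(C3CCCC3)CC(=O)N4)nc2)CC1` likewise gives only a limit, > 30000 nM. The step of an at least 2.2-fold lower number from compound 1 to compound 3 (0.35 log units; beyond the scatter) came from putting methyl in place of hydrogen on an amide-type nitrogen in a ring. Compound 4 `CC1CCN(c2ccc(Nc3ncc4c(n3)N(C3CCCC3)CC(=O)N4C)nc2)CC1` carries the same change that separates compound 2 from compound 1: 4-methylpiperidin-1-yl in place of 4-methylpiperazin-1-yl on an aromatic carbon. The matching step that the two limits leave unreadable from compound 1 to compound 2 cannot be read because both values sit at the limit of > 30000 nM in this assay, at which 2 of the 3 values shown sit. With no readable parallel, a step within the scatter is expected for a 1.1-fold higher number from compound 3 to compound 4 (0.06 log units; within the scatter). Compound 4 is therefore estimated at 15000 nM, within 6000 nM to 40000 nM.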

Compound 4, half-maximal inhibitory concentration: > 30000 nM
Compound 4: a limit, no number; the forecaster's own chance of this, stated with the estimate: 35%; middle value at least 2.0-fold (0.30 log units) away from the limit.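

With the methyl on the amide-type ring nitrogen in place, swapping the piperazine for the piperidine at this position has a readable effect in this assay: the swap gives an at least 2.2-fold higher number from compound 3 to compound 4 (0.35 log units; beyond the scatter). In this one pair, one ring nitrogen fewer goes with weaker inhibition. The steps between compounds that both sit at the limit cannot be read: the limit of > 30000 nM in this assay, at which 3 of the 4 values shown sit.

As far as these compounds go, how far compound 4 lies past its limit stays open. So does whether a morpholine or an unsubstituted piperazine at this position would match compound 3.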